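This account rests on a few compounds, and the source may have more. Where it says the series, first, only, none or still open, it means among the compounds named here.

Measured in an ADME assay on MT4 cells (Homo sapiens) for cytotoxicity, read by MTT assay, with a stated time of 5 days; on this read-out lower numbers stand for higher toxicity in this test and higher numbers for lower toxicity in this test:
- compound 1 `N#Cc1ccc(Nc2nccc(OCC(=O)Nc3cccc(Cl)c3)n2)cc1`: > 329000 nM, a limit
- compound 2 `N#Cc1ccc(Nc2nccc(OCC(=O)Nc3ccc([N+](=O)[O-])cc3)n2)cc1`: > 320000 nM, a limit
- compound 3 `N#Cc1ccc(Nc2nccc(OCC(=O)Nc3ccc(C#N)cc3F)n2)cc1`: > 321000 nM, a limit

Compound 3 stands at > 321000 nM, which is a limit and not a number. With a limit for each of the three compounds, no order among them can be read.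

Compound 4 `COc1ccc(NC(=O)COc2ccnc(Nc3ccc(C#N)cc3)n2)cc1` carries 4-methoxyphenyl in place of 4-cyano-2-fluorophenyl on an amide-type nitrogen. Within the data shown here, no measured compound carries 4-methoxyphenyl.

Among the measured compounds shown here, three measured steps bear on this change, all exchanges on the same nitrogen: a step that the two limits leave unreadable from compound 1 to compound 2, a step that the two limits leave unreadable from compound 1 to compound 3 and a step that the two limits leave unreadable from compound 2 to compound 3. None has a readable size, so they give no measured effect of such an exchange. For the measured compounds named here, they show only that all three groups tried at this place ended in a limit in this assay.

On that basis, no step beyond the scatter is expected in either direction, and a further limit is the likeliest report. The expected change is a step that the limit leaves unreadable from compound 3 to compound 4. For compound 4 the estimate is 330000 nM, with an expected range from 130000 nM to 340000 nM.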

Compound 4, half-maximal cytotoxic concentration: > 333000 nM
Compound 4: no number, only a limit (the forecaster's own chance of this, stated with the estimate: 80%); middle value at least 1.0-fold (0.00 log units) from the limit.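

In this assay compound 4 gives > 333000 nM and this is a limit. The steps from compound 1, compound 2 and compound 3 to compound 4 therefore cannot be read, since all four results are limits. The compounds shown leave open whether any exchange on the amide-type nitrogen changes the half-maximal cytotoxic concentration at all.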